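Methylating the Hydroxy Group: Expected Cytotoxicity of Compound 3

The source may hold more compounds than are shown below. What is called first, only, known or untested is meant among the compounds shown, and "the series" means these compounds.

Compound 2 `COc1nc(O)nc2c1ncn2[C@@H]1O[C@H](CO)[C@@H](O)[C@@]1(C)O` was examined in an ADME assay on Vero cells (Chlorocebus sabaeus) for cytotoxicity, with a stated time of 3 days; a lower number here means that less compound is tolerated, a higher number that more compound is tolerated. In this assay compound 2 gives only a limit, > 100000 nM. Compound 1 `COc1nc(Cl)nc2c1ncn2[C@@H]1O[C@H](CO)[C@@H](O)[C@@]1(C)O` likewise gives only a limit, > 100000 nM. The step from compound 1 to compound 2, a step that the two limits leave unreadable from compound 1 to compound 2, therefore cannot be sized, as shown by the limit of > 100000 nM in this assay, at which 2 of the 2 values shown sit. Compound 3 `COc1nc(OC)c2ncn([C@@H]3O[C@H](CO)[C@@H](O)[C@@]3(C)O)c2n1` differs from compound 2 by methyl in place of hydrogen on an oxygen on an aromatic ring. With both measured values resting at the limit, no step beyond the scatter can be read from them. The expected step is a number no higher from compound 2 to compound 3 (the limit leaves the size open). Compound 3 is estimated at 100000 nM, within 50000 nM to 300000 nM.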

Compound 3, half-maximal cytotoxic concentration: > 100000 nM
Compound 3 gave a limit, no number; the forecaster's own chance of this, stated with the estimate: 85%; the middle value lies on the limit itself.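

In this assay compound 3 gives > 100000 nM, which is a limit and not a number. Among the compounds shown here, no step among compound 1, compound 2 and compound 3 can therefore be read: the limit of > 100000 nM in this assay, at which 3 of the 3 values shown sit. The compounds shown leave open whether chloro, hydroxy or methoxy on the shared core changes this read-out at all.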